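Sulfonamide series: carbamoyl to trifluoromethyl on the aryl ring

The compounds below may be only part of what the source reports. "The series", "measured", "known", "first", "only" and "open" are said of these compounds alone.

Of the compounds shown here, two measured so far. In an assay on isolated protein for inhibition of alkaline phosphatase, tissue-nonspecific isozyme (Homo sapiens) (on this read-out higher numbers stand for weaker inhibition and lower numbers for stronger inhibition), compound 2 `COc1ccc(C(N)=O)cc1S(=O)(=O)Nc1cccnc1` gives 1490 nM, the lowest of the two numbers; compound 1 `COc1cc(Cl)ccc1S(=O)(=O)Nc1cccnc1` gives 4170 nM in this assay, a gap beyond the usual scatter. Compound 3 `COc1ccc(C(F)(F)F)cc1S(=O)(=O)Nc1cccnc1` is not yet measured. It differs from compound 2 by trifluoromethyl in place of carbamoyl on an aromatic carbon. Among the measured compounds shown here, no measured pair shows this change, so the direction rests only on the two values of compound 1 and compound 2. Expected step from compound 2 to compound 3 in this assay: a 2.0-fold higher number from compound 2 to compound 3 (0.30 log units; within the scatter), a modest shift toward weaker inhibition. Compound 3 is estimated at 3000 nM, within 1000 nM to 9000 nM.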

Compound 3, half-maximal inhibitory concentration: 183 nM
Compound 3: the middle estimate sits 16-fold (1.21 log units) above what was measured, outside the stated range (below it).
By their numbers in this assay, from the lowest: compound 3; then compound 2; then compound 1.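

In this assay, trifluoromethyl in place of carbamoyl on the aromatic carbon para to the methoxy group gives an 8.1-fold lower number from compound 2 to compound 3 (0.91 log units; beyond the scatter), so inhibition at this position does not depend on the hydrogen-bond donor and acceptor of carbamoyl. The position is also clearly sensitive to the group it carries, with a single change moving the value beyond the scatter. Nothing at hand explains the size or direction of this step.

Open, going by these compounds, is whether a nitrile, a methyl or a carboxylic acid on the same carbon would match trifluoromethyl. Also open, on these data alone, is whether the gain survives replacing the methoxy group with an ethoxy group.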